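Extending Ethyl to Butyl on the Imidazole Arm

The source may hold more compounds than are shown below. What is called first, only, known or untested is meant among the compounds shown, and "the series" means these compounds.

Of the compounds shown here, three sharing one core have been measured in an assay on isolated protein for displacement of a labelled ligand from Gonadotropin-releasing hormone receptor (Homo sapiens); a lower number here means a stronger inhibitor, a higher number a weaker inhibitor. Compound 1 `Cc1nc(C)c(CN2CCN(c3cccc4[nH]c(-c5ccc(C(C)(C)C)cc5)nc34)CC2)s1` gives 27 nM. Compound 2 `Cc1cc(CN2CCN(c3cccc4[nH]c(-c5ccc(C(C)(C)C)cc5)nc34)CC2)nn1C` gives 83 nM, and compound 3 `CCc1nc(CN2CCN(c3cccc4[nH]c(-c5ccc(C(C)(C)C)cc5)nc34)CC2)cn1C` gives 18 nM. Compound 3 thus holds the lowest number of the three: its step from compound 1 lies within the scatter, a 1.5-fold lower number from compound 1 to compound 3 (0.18 log units; within the scatter), while its step from compound 2 lies beyond it, a 4.6-fold lower number from compound 2 to compound 3 (0.66 log units; beyond the scatter); the step of a 3.1-fold higher number from compound 1 to compound 2 (0.49 log units; beyond the scatter) separates the other two. Compound 4 `CCCCc1nc(CN2CCN(c3cccc4[nH]c(-c5ccc(C(C)(C)C)cc5)nc34)CC2)cn1C` differs from compound 3 by ethyl in place of hydrogen on a saturated chain carbon, two bonds along the chain from an aromatic carbon; cut one bond further out, the change reads ethyl to butyl, so the 2-ethyl-1-methyl-1H-imidazol-4-yl becomes 2-butyl-1-methyl-1H-imidazol-4-yl. Going by the values given here, none of the measured steps touches this chain; all three exchange one heteroaryl ring for another, and their sizes, from within the scatter up to modest, set the scale of change seen so far. Among the compounds with values here, with no direct precedent, a step of no more than modest size in this assay is expected for compound 4, in either direction, and most likely within the scatter. Compound 4 is therefore estimated at 25 nM, between 8 nM and 80 nM, which is expected to mean a 1.4-fold higher number from compound 3 to compound 4 (0.14 log units; within the scatter).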

Compound 4, half-maximal inhibitory concentration: 26 nM
The estimate for compound 4 lay 1.0-fold (0.02 log units) below the measured number, within the range that was stated.
By their numbers in this assay, from the lowest: compounds 3, 4 and 1 (each within the scatter of the next); then compound 2.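

In this assay, going by these compounds alone, the step on the chain itself is small (a 1.4-fold higher number from compound 3 to compound 4 (0.16 log units; within the scatter)): ethyl in place of hydrogen on a saturated chain carbon, two bonds along the chain from an aromatic carbon, leaves the number within the scatter, whereas the earlier steps all exchanged one heteroaryl ring for another. The 2-butyl-1-methyl-1H-imidazol-4-yl arm also stands where the 2-ethyl-1-methyl-1H-imidazol-4-yl arm stood relative to the other two rings: it remains clearly apart from the 1,5-dimethyl-1H-pyrazol-3-yl compound (a 3.2-fold lower number from compound 2 to compound 4 (0.50 log units; beyond the scatter)) and cannot be told apart from the 2,4-dimethyl-1,3-thiazol-5-yl compound (a 1.0-fold lower number from compound 1 to compound 4 (0.02 log units; within the scatter)). No supporting evidence bears on this result, so the account rests on these numbers alone.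

The compounds shown leave open whether this tolerance continues to a longer chain such as hexyl, or holds for a branched group such as isopropyl or a shorter one such as methyl on the same ring. They also leave open whether a butyl chain ending in a hydroxyl group, an amine or a carboxylic acid would give a number in the same range.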